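The source may hold more compounds than are shown below. What is called first, only, known or untested is meant among the compounds shown, and "the series" means these compounds.

Of the compounds shown here, three sharing one core have been measured in an assay on isolated protein for inhibition of Nicotinamide phosphoribosyltransferase (Homo sapiens), read by mass spectrometry, with stated times of 15 min and 30 min; a higher number here means a weaker inhibitor, a lower number a stronger inhibitor. Compound 1 `O=C(NCc1ccc(S(=O)(=O)c2cncc(C(F)(F)F)c2)cc1)N1Cc2ccncc2C1` gives 15 nM, compound 2 `O=C(NCc1ccc(S(=O)(=O)N2CCC(O)CC2)cc1)N1Cc2ccncc2C1` gives 44 nM, and compound 3 `CN1CCN(S(=O)(=O)c2ccc(CNC(=O)N3Cc4ccncc4C3)cc2)CC1` gives 38 nM. Compound 3 thus stands second highest of the three numbers: its nearest neighbour is compound 2, with a 1.2-fold lower number from compound 2 to compound 3 (0.06 log units; within the scatter) separating them, while the furthest is compound 1, separated by a 2.5-fold higher number from compound 1 to compound 3 (0.40 log units; beyond the scatter). Compound 4 `O=C(NCc1ccc(S(=O)(=O)N2CC3(CCOCC3)C2)cc1)N1Cc2ccncc2C1` differs from compound 3 by a group of 9 heavy atoms (7 carbon, 1 nitrogen, 1 oxygen; one four-membered non-aromatic ring with 1 hetero atom, one six-membered non-aromatic ring with 1 hetero atom) in place of a group of 7 heavy atoms (5 carbon, 2 nitrogen; one six-membered non-aromatic ring with 2 hetero atoms), on a sulfonyl sulfur. The step that bears most directly on this is a 1.2-fold lower number from compound 2 to compound 3 (0.06 log units; within the scatter), where one saturated six-membered group on the sulfonyl sulfur was exchanged for another; a 2.9-fold higher number from compound 1 to compound 2 (0.47 log units; beyond the scatter) and a 2.5-fold higher number from compound 1 to compound 3 (0.40 log units; beyond the scatter) are larger but concern the loss of the aromatic group rather than an exchange between saturated ones. Compound 4 keeps a saturated, uncharged group with one acceptor on that sulfur, so the expected step in this assay from compound 3 to compound 4 is a 1.1-fold higher number from compound 3 to compound 4 (0.02 log units; within the scatter), no more than the scatter. The value for compound 4 is therefore estimated at 40 nM, within 15 nM to 110 nM.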

Compound 4, half-maximal inhibitory concentration: 20 nM
Beside the measured number, compound 4's estimate is 2.0-fold (0.30 log units) above it, within the range that was stated.
By their numbers in this assay, from the lowest: compounds 1, 4, 3 and 2 (each within the scatter of the next, the first and the last beyond it).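

In this assay, going by these compounds alone, the group of 9 heavy atoms with its four-membered and six-membered rings is the first saturated group on the sulfonyl sulfur to stand clear of another saturated one, with a 2.2-fold lower number from compound 2 to compound 4 (0.34 log units; beyond the scatter), although a 1.9-fold lower number from compound 3 to compound 4 (0.28 log units; within the scatter) stays within the scatter. Within the data shown here, it is also the first saturated group that cannot be told apart from the aromatic group of compound 1, with a 1.3-fold higher number from compound 1 to compound 4 (0.12 log units; within the scatter), whereas both single-ring saturated groups lay beyond the scatter from it, so an aromatic group on this sulfur is not required for a value in that range. Nothing available here accounts for these steps.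

On these data alone, it remains open whether a morpholin-4-yl group, with its oxygen in a single ring, or an azetidin-1-yl group, with the four-membered ring alone, would give a similar value. As far as these compounds go, how a plain phenyl group on that sulfur would compare with the 5-(trifluoromethyl)pyridin-3-yl group also remains open.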